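Moving the bromine from 3-bromobenzyl to 4-bromobenzyl

The source may report more compounds than this note shows. Statements on the series, on what has been measured and on what is new or still open speak of the compounds shown alone.

Measured so far:
- compound 1 `Brc1ccccc1CSc1nnc(-c2cnccn2)n1-c1ccccc1` gives 11600 nM
- compound 2 `Brc1cccc(CSc2nnc(-c3cnccn3)n2-c2ccccc2)c1` gives 10600 nM

Among the compounds with values here, in a functional assay on HepG2 cells (Homo sapiens) for antiproliferative activity, read by MTT assay, with a stated time of 48 h (on this read-out higher numbers stand for weaker inhibition and lower numbers for stronger inhibition), compound 2 (10600 nM) cannot be told apart from compound 1 (11600 nM), the only other compound measured. The two stand level within the scatter.

The next compound, compound 3 (`Brc1ccc(CSc2nnc(-c3cnccn3)n2-c2ccccc2)cc1`), has not yet been measured. Its difference from compound 2 is 4-bromophenyl in place of 3-bromophenyl on a saturated chain carbon bound to a sulfur and amounts to 4-bromophenyl in place of 3-bromophenyl on a saturated chain carbon bound to a sulfur.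

Within the data shown here, only one measured step bears on this. It is a 1.1-fold lower number from compound 1 to compound 2 (0.04 log units; within the scatter) and it swaps 2-bromophenyl for 3-bromophenyl at the same place, a change of the same kind that stayed within the scatter. Among the measured compounds shown here, a single step makes no pattern, and no measured compound yet carries 4-bromophenyl, so the forecast is cautious and the range is wide. The estimate means a 1.1-fold lower number from compound 2 to compound 3 (0.03 log units; within the scatter) and that is expected to stay within the scatter, with no firm direction. Compound 3 is estimated at 10000 nM (4500 nM to 22000 nM).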

Compound 3, half-maximal inhibitory concentration: 11400 nM
Beside the measured number, compound 3's estimate is 1.1-fold (0.06 log units) below it; low and high end bracket the measured number.
By their numbers in this assay, from the lowest: compounds 2, 3 and 1 (each within the scatter of the next).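

In this assay, the 4-bromophenyl group completes the set of bromophenyl groups on a saturated chain carbon bound to a sulfur: the change from 3-bromophenyl gives a 1.1-fold higher number from compound 2 to compound 3 (0.03 log units; within the scatter), and the change from 2-bromophenyl gives a 1.0-fold lower number from compound 1 to compound 3 (0.01 log units; within the scatter). The earlier pair had shown only that 2-bromophenyl and 3-bromophenyl could not be told apart, whereas these steps extend that finding to 4-bromophenyl, so that moving the bromine among these three named groups has no effect this read-out can resolve. No measurement available here accounts for this level result.

The compounds shown leave open whether the bromine itself contributes anything, since all three carry it and none has a plain benzyl group, a chlorine or a methoxy group in its place. They also leave open what would happen with a quite different group at this place, such as an amine or a carboxylic acid on the ring, or a longer chain between the sulfur and the ring.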